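This account rests on a few compounds, and the source may have more. Where it says the series, first, only, none or still open, it means among the compounds named here.

Measured compounds:
- compound 1, `O=C(c1cc(-c2ccccc2)c2cc(I)ccc2n1)N1CCOCC1`: 29900 nM
- compound 2, `O=C(c1cc(-c2ccccc2I)c2ccccc2n1)N1CCOCC1`: 929 nM

In an assay on brain (strain Sprague-Dawley) for displacement of a labelled ligand from Translocator protein (Rattus norvegicus), read by scintillation counting, with a stated time of 90 min (a lower number here means a stronger inhibitor, a higher number a weaker inhibitor), compound 2 gives the lower of the two numbers, and the gap to compound 1 lies beyond the ordinary scatter of the measurement, so compound 2 is the stronger binder of the two. Compound 3, `CCN(CC)C(=O)c1cc(-c2ccccc2I)c2ccccc2n1`, is not yet measured. It differs from compound 2 in one place only: diethylamino in place of morpholin-4-yl on a carbonyl carbon. The amide part is kept, only the group on its nitrogen changes. Going by the values given here, no step between two measured compounds shows what this exchange does, so the expectation rests on the one measured value of compound 2 alone. A moderate move towards a lower number is expected, a 3.7-fold lower number from compound 2 to compound 3 (0.57 log units; beyond the scatter), though a result within the scatter of compound 2 would not be surprising. For compound 3 in this assay a value of about 250 nM is estimated, with a likely range from 50 nM to 1200 nM.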

Compound 3, inhibition constant: 5.01 nM
Compound 3: the middle estimate sits 50-fold (1.70 log units) above what was measured; the whole stated range lies above it.
By their numbers in this assay, from the lowest: compound 3; then compound 2; then compound 1.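

Within this assay, the group on the amide nitrogen proves to be a highly sensitive point: a 190-fold lower number from compound 2 to compound 3 (2.27 log units; beyond the scatter) follows from this one exchange on the carbonyl carbon, while the rest of the molecule stays the same. The exchange takes away both the ring and the oxygen of morpholin-4-yl, and this single step cannot show which of the two matters. No measurement shown here explains the large change in binding.

Piperidin-1-yl, which has a six-membered ring without the oxygen, would separate those two changes, while dimethylamino and dipropylamino would test how the result depends on chain length. Going by these compounds, it also remains open whether diethylamino would give a similar step when the iodine sits where it does in compound 1.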